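Swapping fluoro for bromo on compound 1's aryl ring

The source may report more compounds than this note shows. Statements on the series, on what has been measured and on what is new or still open speak of the compounds shown alone.

Measured so far:
compound 1 `N=C(N)c1ccc2[nH]c(-c3cc(F)cc(Br)c3)cc2c1` — 93%
compound 2 `COc1cc(F)cc(-c2cc3cc(C(=N)N)ccc3[nH]2)c1` — 77%

In an assay on isolated protein for inhibition of acid-sensing ion channel 3 (Homo sapiens), read by patch clamp, tested at 1 uM (on this read-out lower numbers stand for less inhibition and higher numbers for more inhibition at the one concentration tested (going by the name of the read-out)), compound 1 gives 93%, the higher of the two numbers; compound 2 lies a number 16 percentage points lower from compound 1 to compound 2 (beyond the scatter). The unmeasured compound 3 `N=C(N)c1ccc2[nH]c(-c3cc(Br)cc(Br)c3)cc2c1` differs from compound 1 by bromo in place of fluoro on an aromatic carbon. Among the compounds with values here, the only measured step changes a different group, bromo to methoxy, and gives no guide for fluoro to bromo. Within the data shown here, with no bearing step, the expected change is a number 3 percentage points lower from compound 1 to compound 3 (within the scatter), none beyond the scatter. Compound 3 is therefore estimated at 90%, between 78% and 98%.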

Compound 3, a percentage reported as inhibition, at one concentration (the size of the read-out at that concentration, not a potency): 92%
Compound 3: the middle estimate sits 2 percentage points below what was measured; the measured number falls inside the stated range.
By their numbers in this assay, from the lowest: compound 2; then compounds 3 and 1 (each within the scatter of the next).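

Bromo in place of fluoro on this aromatic carbon gives a number 1 percentage points lower from compound 1 to compound 3 (within the scatter) in this assay and so does not separate the two groups. At this position, a bromo group serves as well as a fluoro group, with no loss beyond the scatter. No measurement shown explains this result. On these data alone, with only one concentration tested, any difference in potency between compound 1 and compound 3 stays open. So does the effect of an amine or a carboxylic acid on this same carbon.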